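Methyl in Place of Chloro on a Shared Core

The compounds below may be only part of what the source reports. "The series", "measured", "known", "first", "only" and "open" are said of these compounds alone.

Of the compounds shown here, three built on the same core have been measured in a functional assay on ileum (strain Hartley) for agonist activity at 5-hydroxytryptamine receptor 3A (Cavia porcellus); a higher number here means a more potent compound, by a factor of ten per unit of this negative logarithm, a lower number a less potent compound. Compound 1 `CN1CCN(c2nc3cc([N+](=O)[O-])ccc3o2)CC1` gives 6.1 in this assay. Compound 2 `Cc1cc(Cl)c2oc(N3CCN(C)CC3)nc2c1` gives 6.22, and compound 3 `COc1cc(Cl)cc2nc(N3CCN(C)CC3)oc12` gives 6.16. The number for compound 2 is the highest of the three, but its gap to compound 3 and its gap to compound 1 both lie within the usual scatter, so the three compounds cannot be told apart on these data.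

Compound 4 `Cc1cc(C)c2oc(N3CCN(C)CC3)nc2c1` has not yet been measured. It differs from compound 2 in one place: methyl in place of chloro on an aromatic carbon, a methyl in place of chloro on an aromatic carbon. Among the compounds with values here, no measured pair here shows what such an exchange does in this assay, and the three numbers in hand lie close together. The expectation for compound 4 is therefore a step from compound 2 of a number 0.12 log units lower from compound 2 to compound 4 (within the scatter), which is none beyond the scatter. Compound 4 is estimated at 6.1, with a range from 5.6 to 6.6.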

Compound 4, negative logarithm of the half-maximal effective concentration: 6.32
Beside the measured number, compound 4's estimate is 0.22 log units below it; the measured number falls inside the stated range.
By their numbers in this assay, from the lowest: compounds 1, 3, 2 and 4 (each within the scatter of the next).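

In this assay, within the data shown here, the exchange of chloro for methyl on this aromatic carbon, meta to a methyl group, gives the only pair here that differs in one place, and its step is within the scatter: a number 0.10 log units higher from compound 2 to compound 4 (within the scatter). At this position, then, chloro can give way to methyl, another group of one heavy atom, with no change that these data can separate from repeat variation, so the chlorine is not required to hold the number at this level. Nothing on hand speaks to what lies behind this result.

From the compounds shown here alone, whether an amine or a longer chain on this same carbon would keep the number in this range remains open. Going by these compounds, it also remains open whether the same exchange would read alike at another carbon of the shared core.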